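The source may hold more compounds than are shown below. What is called first, only, known or untested is meant among the compounds shown, and "the series" means these compounds.

Two analogues of the shared core have been measured. In a functional assay on MCF7 cells (Homo sapiens) for antiproliferative activity (a higher number here means a weaker inhibitor, a lower number a stronger inhibitor), compound 1 `CCCCn1c(Cc2c(Br)c(OC)c(OC)c(OC)c2Br)nc2c(N)ncnc21` gives 30200 nM, and compound 2 `COc1cc(Cc2nc3c(N)ncnc3n2CC2CC2)cc(OC)c1OC` gives 75900 nM, the higher of the two numbers, with a gap to compound 1 that lies beyond the scatter. Compound 3 `C/C=C/Cn1c(Cc2cc(OC)c(OC)c(OC)c2)nc2c(N)ncnc21` is not yet measured; it differs from compound 2 by prop-1-en-1-yl in place of cyclopropyl on a saturated chain carbon bound to an aromatic nitrogen. Going by the values given here, no measured pair shows this change, so nothing anchors its size. The expected step is a 1.3-fold lower number from compound 2 to compound 3 (0.10 log units; within the scatter), with no direction beyond the scatter. For compound 3 the estimate in this assay is 60000 nM, with a range from 25000 nM to 150000 nM.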

Compound 3, half-maximal inhibitory concentration: 51300 nM
Compound 3: the middle estimate sits 1.2-fold (0.07 log units) above what was measured; the range from low to high includes it.
By their numbers in this assay, from the lowest: compounds 1, 3 and 2 (each within the scatter of the next, the first and the last beyond it).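

Prop-1-en-1-yl in place of cyclopropyl on a saturated chain carbon bound to an aromatic nitrogen gives a 1.5-fold lower number from compound 2 to compound 3 (0.17 log units; within the scatter) in this assay. Going by these compounds alone, this is the first one-place comparison, and it does not separate the ring-bearing cyclopropylmethyl from the open-chain but-2-en-1-yl at this position. Neither group stands apart from the other in this read-out.

On these data alone, whether a longer chain, an amine or a carboxylic acid at this position would move the number beyond the scatter remains open. No available evidence accounts for the result.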